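This account rests on a few compounds, and the source may have more. Where it says the series, first, only, none or still open, it means among the compounds named here.

Compound 1 `CCN(CC)CCCCOc1c(OC)cc2oc(-c3ccccc3)cc(=O)c2c1O`: 35000 nM
Compound 2 `COc1cc2oc(-c3ccccc3)cc(=O)c2c(O)c1OCCCCN1CCCCC1`: 34000 nM

Both compounds share the same core and differ only in the amine at the end of the chain that hangs from the ring oxygen. In a functional assay on A549 cells (Homo sapiens) for antiproliferative activity, read by MTT assay, with a stated time of 48 h (on this read-out higher numbers stand for weaker inhibition and lower numbers for stronger inhibition), compound 1 gives 35000 nM and compound 2 gives 34000 nM. The step from one to the other is a 1.0-fold lower number from compound 1 to compound 2 (0.01 log units; within the scatter), so the two values cannot be told apart; compound 2 stands at one end of these two numbers only by a margin that means nothing.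

Compound 3 `COc1cc2oc(-c3ccccc3)cc(=O)c2c(O)c1OCCCN1CCN(C)CC1` is the next member. Its difference from compound 2 is 4-methylpiperazin-1-yl in place of (piperidin-1-yl)methyl on a saturated chain carbon, three bonds along the chain from an oxygen on an aromatic ring: one ring amine is swapped for another, and the chain linking it to the ring oxygen becomes one carbon shorter.

Within the data shown here, the only measured step that bears on this is the swap of the amine at the end of the chain, which was a 1.0-fold lower number from compound 1 to compound 2 (0.01 log units; within the scatter) and within the scatter. That swap gave no movement, and the present change is of the same family, with a second ring nitrogen added and the chain trimmed. No step beyond the scatter is therefore expected. In this assay compound 3 is estimated at 34000 nM, with a range from 15000 nM to 75000 nM, which means an expected step of no change at the digits printed from compound 2 to compound 3 (within the scatter).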

Compound 3, half-maximal inhibitory concentration: 18000 nM
Estimate against measurement, compound 3: 1.9-fold (0.28 log units) above; low and high end bracket the measured number.
By their numbers in this assay, from the lowest: compounds 3, 2 and 1 (each within the scatter of the next).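

Replacing 4-(piperidin-1-yl)butyl with 3-(4-methylpiperazin-1-yl)propyl gives a 1.9-fold lower number from compound 2 to compound 3 (0.28 log units; within the scatter) in this assay, and the comparison with the diethylamino member gives a 1.9-fold lower number from compound 1 to compound 3 (0.29 log units; within the scatter) on the same read-out. The earlier step changed only the amine, whereas these steps bring a second ring nitrogen and a shorter chain together, and still neither leaves the scatter, so the three compounds cannot be ranked against one another. The data offer no measurement that could account for these numbers.

Compound 3 differs from compound 2 in both the ring amine and the chain, leaving the contribution of each change unresolved; a 4-(4-methylpiperazin-1-yl)butyl group on the shared core would separate the two. On these data alone, it also remains open whether a different amine, such as morpholin-4-yl, or a longer chain, such as a hexyl linker ending in piperidin-1-yl, would move the number beyond the scatter.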